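Replacing an aromatic ring with tert-butyl on the amide nitrogen

The compounds below may be only part of what the source reports. "The series", "measured", "known", "first", "only" and "open" are said of these compounds alone.

Measured compounds:
compound 1 `Cc1ccc(OCC(=O)N(Cc2cccs2)c2ccon2)cc1`, 2 nM
compound 2 `CCN(Cc1nccs1)C(=O)COc1ccc(C)cc1`, 3060 nM

Of the compounds shown here, two have been measured in an assay on HEK293 cells for agonist activity at transient receptor potential cation channel subfamily M member 8 (Homo sapiens), read by fluorescence and calcium flux, with a stated time of 15 min; a lower number here means that less compound is needed, a higher number that more compound is needed for the effect. Compound 1 gives 2 nM, the lowest of the two numbers. Compound 2 differs from compound 1 in several places at once. Compound 2 gives 3060 nM, a far higher number, well beyond the scatter of repeated runs. Within the data shown here, no single-change step between measured compounds is available, so the gap between them cannot be assigned to one part of the structure.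

The next compound, compound 3 `Cc1ccc(OCC(=O)N(Cc2cccs2)C(C)(C)C)cc1`, differs from compound 1 in one place only: tert-butyl in place of 1,2-oxazol-3-yl on an amide-type nitrogen. The 1,2-oxazol-3-yl group that leaves carries a five-membered aromatic ring with two hetero atoms and two hydrogen-bond acceptors; the tert-butyl group that enters has no ring and no acceptors. Among the measured compounds shown here, compound 2, the only other measured compound, has a small saturated group on that nitrogen and a much higher number, though it is not a clean comparison.

Compound 3 is therefore expected to show a sizeable step toward a higher number, a 150-fold higher number from compound 1 to compound 3 (2.18 log units; beyond the scatter), in this assay. The estimate for compound 3 is 300 nM, with a plausible range from 30 nM to 3000 nM.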

Compound 3, half-maximal effective concentration: 11000 nM
Beside the measured number, compound 3's estimate is 37-fold (1.56 log units) below it, outside the stated range (above it).
By their numbers in this assay, from the lowest: compound 1; then compound 2; then compound 3.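

In this assay, among these compounds, the single change on the amide-type nitrogen gives a 5500-fold higher number from compound 1 to compound 3 (3.74 log units; beyond the scatter) and the rest of the structure stays the same, so this one position can carry a very large step on its own, which the earlier pair could not show. The change takes away 1,2-oxazol-3-yl, with its five-membered aromatic ring and two hydrogen-bond acceptors, and puts in tert-butyl, with no ring and no acceptors, so ring and acceptors leave together and this step cannot separate their contributions. The data shown offer no independent measurement that would explain the size of this step.

The compounds shown leave open whether a plain phenyl ring on that nitrogen, which has a ring but no acceptors, would keep the number low, or whether a methoxyethyl chain, which has an acceptor but no ring, would do so. Going by these compounds, it also remains open whether a pyridine ring or another five-membered aromatic ring, such as a pyrazole, could take the place of 1,2-oxazol-3-yl there and give a number close to that of compound 1.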